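Replacing a sulfur-bearing chain with a basic amine on the core

A few compounds are considered here, and "the series" means these few. Any claim that something is new, unique, unknown or untested is made for them only; others in the source may bear on it.

Three compounds share one core, varying only the chain on the ring nitrogen. Compound 1 `CNS(=O)(=O)CCn1c(=N)sc2cc(OC(F)(F)F)ccc21` in a functional assay on the whole organism with Rattus norvegicus as the target (a higher number here means that more compound is needed for the effect, a lower number that less compound is needed), gives 4 mg/kg. Compound 2 `CN(C)S(=O)(=O)CCn1c(=N)sc2cc(OC(F)(F)F)ccc21` in this assay reaches only the assay limit of > 10 mg/kg. Compound 3 `CSCn1c(=N)sc2cc(OC(F)(F)F)ccc21` in this assay gives 3 mg/kg, the lowest number among the three, with compound 1 nearest; that pair differs by a 1.3-fold lower number from compound 1 to compound 3 (0.12 log units; within the scatter), whereas an at least 3.3-fold lower number from compound 2 to compound 3 (0.52 log units; beyond the scatter) and an at least 2.5-fold higher number from compound 1 to compound 2 (0.39 log units; beyond the scatter) lie beyond the scatter, the latter with compound 2 sitting at the limit of > 10 mg/kg in this assay, at which 1 of the 3 values shown sits.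

The next compound, compound 4 `CN(C)CCCn1c(=N)sc2cc(OC(F)(F)F)ccc21`, differs from compound 3 by 2-(dimethylamino)ethyl in place of methylsulfanyl on a saturated chain carbon bound to an aromatic nitrogen. For the measured compounds named here, no measured step changes this chain in the same way, and the only step that adds methyls on a nitrogen, an at least 2.5-fold higher number from compound 1 to compound 2 (0.39 log units; beyond the scatter), points toward a higher number. Compound 4 is therefore expected to show a modest rise in this assay, a 1.7-fold higher number from compound 3 to compound 4 (0.22 log units; within the scatter), so its number in this assay is estimated at 5 mg/kg, ranging from 1.5 mg/kg to 15 mg/kg.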

Compound 4, dose for half-maximal effect: 9 mg/kg
Compound 4: the middle estimate sits 1.8-fold (0.26 log units) below what was measured; the range from low to high includes it.
By their numbers in this assay, from the lowest: compounds 3 and 1 (each within the scatter of the next); then compound 4. At a limit, above all of these: compound 2.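

Putting 3-(dimethylamino)propyl in place of (methylsulfanyl)methyl on the shared core gives a 3.0-fold higher number from compound 3 to compound 4 (0.48 log units; beyond the scatter) in this assay, and the change from the methylsulfamoyl chain gives a 2.3-fold higher number from compound 1 to compound 4 (0.35 log units; beyond the scatter). Compound 4 thus shows that this position responds to a change of chain type, and that the amine-ended chain needs more compound here than the sulfur-bearing chains of compound 1 and compound 3. The remaining step, an at least 1.1-fold lower number from compound 2 to compound 4 (0.04 log units; that floor lies within the scatter), settles no order, with its floor within the scatter and compound 2 standing at a limit: the limit of > 10 mg/kg in this assay, at which 1 of the 4 values shown sits.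

The compounds shown leave open whether the rise follows the dimethylamino group itself or the chain that carries it. A primary amine, a morpholine or a carboxylic acid at the end of this chain could help separate the two.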